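The compounds below may be only part of what the source reports. "The series", "measured", "known", "first", "only" and "open" are said of these compounds alone.

Compound 1, `Cc1cnc(Nc2ccc(C(C)C)cc2)nc1Nc1nc2ccccc2s1`. In a functional assay on MCF7 cells (Homo sapiens) for antiproliferative activity, read by MTT assay, with a stated time of 48 h (on this read-out lower numbers stand for stronger inhibition and higher numbers for weaker inhibition), compound 1 gives > 50000 nM, which is a limit of the assay and not a number.
Compound 2, `Cc1cnc(Nc2ccc([N+](=O)[O-])cc2)nc1Nc1nc2ccccc2s1`. In this assay compound 2 gives > 50000 nM, again a limit rather than a number.
Compound 3, `COc1cccc(Nc2ncc(C)c(Nc3nc4ccccc4s3)n2)c1`. In this assay compound 3 gives > 50000 nM, also a limit.

Within the data shown here, compound 3 therefore stands where the whole set stands: every measured value sits at the limit of > 50000 nM in this assay, at which 3 of the 3 values shown sit, and no compound can be placed above or below another. The three measured steps are each of the same kind: a step that the two limits leave unreadable from compound 1 to compound 2, a step that the two limits leave unreadable from compound 1 to compound 3 and a step that the two limits leave unreadable from compound 2 to compound 3. None of them can be read for size or direction.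

Compound 4, `Cc1cnc(Nc2ccc(F)cc2)nc1Nc1nc2ccccc2s1`, differs from compound 3 in one place: 4-fluorophenyl in place of 3-methoxyphenyl on a nitrogen on an aromatic ring. All three measured steps change the group on that same nitrogen, and each of them is unreadable, so none gives a readable guide to the step now in question. With nothing in the measured set showing any step beyond the scatter, compound 4 is expected to remain at the limit as well, which is expected to mean a number no higher from compound 3 to compound 4 (the limit leaves the size open) in this assay. The estimate for compound 4 is 50000 nM, with a range from 20000 nM to 150000 nM.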

Compound 4, half-maximal inhibitory concentration: > 50000 nM
Compound 4: a limit, no number (the forecaster's own chance of this, stated with the estimate: 80%); the middle value sits exactly at the limit.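

Compound 4 also sits at a limit and not at a number, so no new step from compound 1, compound 2 or compound 3 to compound 4 can be read in this assay: the limit of > 50000 nM in this assay, at which 4 of the 4 values shown sit.

The compounds shown leave open how far any of them lies from that limit, and whether changing the group on that nitrogen alters the read-out at all.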